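The compounds below may be only part of what the source reports. "The series", "measured", "known", "first", "only" and "open" are said of these compounds alone.

Compound 1, `Clc1ccc(NCc2cn(-c3ccccc3)nc2-c2ccc(Cl)cc2)cc1`: 2450 nM in a functional assay on B16-F10 cells (Mus musculus) for antiproliferative activity, read by MTT assay, with a stated time of 48 h; on this read-out lower numbers stand for stronger inhibition and higher numbers for weaker inhibition
Compound 2, `Cc1ccc(-c2nn(-c3ccccc3)cc2CNc2ccc(Cl)cc2)cc1`: 6010 nM in this assay
Compound 3, `COc1ccc(-c2nn(-c3ccccc3)cc2CNc2ccc(Cl)cc2)cc1`: 7180 nM in this assay

Compound 3 has the highest of the three numbers in this assay. Its neighbour is compound 2, a 1.2-fold higher number from compound 2 to compound 3 (0.08 log units; within the scatter), a gap within the scatter, so the two cannot be ordered. Compound 1 lies further off, a 2.9-fold higher number from compound 1 to compound 3 (0.47 log units; beyond the scatter), and that gap is beyond the scatter.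

The next compound, compound 4, is `Clc1ccc(NCc2cn(-c3ccccc3)nc2-c2ccc(Br)cc2)cc1`. It differs from compound 3 in one place: bromo in place of methoxy on an aromatic carbon.

Among the compounds with values here, two measured steps bear on this change, since both replace a chloro at the same aromatic carbon. From compound 1 to compound 2 the number rose, a 2.5-fold higher number from compound 1 to compound 2 (0.39 log units; beyond the scatter), and from compound 1 to compound 3 it rose further, a 2.9-fold higher number from compound 1 to compound 3 (0.47 log units; beyond the scatter). Compound 4 carries a bromo, a halogen as in compound 1, so the change from compound 3 to compound 4 is expected to undo most of the rise seen from compound 1 to compound 3, giving a lower number beyond the scatter, a 2.6-fold lower number from compound 3 to compound 4 (0.41 log units; beyond the scatter).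

Compound 4 is therefore expected to give about 2800 nM in this assay, within a range from 1400 nM to 5600 nM.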

Compound 4, half-maximal inhibitory concentration: 4290 nM
Compound 4: middle estimate off by 1.5-fold (0.19 log units), on the low side; measured number inside the range.
By their numbers in this assay, from the lowest: compounds 1, 4, 2 and 3 (each within the scatter of the next, the first and the last beyond it).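

In this assay the bromo at this aromatic carbon cannot be told apart from any of the three groups seen there before: replacing methoxy gives a 1.7-fold lower number from compound 3 to compound 4 (0.22 log units; within the scatter), replacing methyl gives a 1.4-fold lower number from compound 2 to compound 4 (0.15 log units; within the scatter), and replacing chloro gives a 1.8-fold higher number from compound 1 to compound 4 (0.24 log units; within the scatter). Compound 1 and compound 3 remain separated beyond the scatter, as do compound 1 and compound 2, yet compound 4 lies within the scatter of all three, so it falls clearly on neither side of that gap. The earlier separation of chloro from methyl and methoxy therefore does not extend to a second halogen as a clear shared trend, and no measurement at hand explains these values.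

From the compounds shown here alone, whether an amine, a carboxylic acid or a longer chain at this aromatic carbon would move the number outside the span of these four compounds remains open. Also open, going by these compounds, is whether the small differences among bromo, methyl and methoxy would hold up in repeated measurements or on cells other than those of this assay.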